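The source may hold more compounds than are shown below. What is called first, only, known or untested is meant among the compounds shown, and "the series" means these compounds.

Measured compounds:
- compound 1, `CCCc1ccc(/C=C/C(=O)Nc2ccc3nc(CCC)cc(N)c3c2)cc1`: 4 nM
- compound 2, `Nc1cc(-c2ccccc2)nc2ccc(NC(=O)/C=C/c3ccc(C(F)(F)F)cc3)cc12`: 18.5 nM
- compound 3, `CC(C)(C)c1cc(N)c2cc(NC(=O)/C=C/c3ccc(C(F)(F)F)cc3)ccc2n1`: 0.3 nM

In an assay on isolated protein for displacement of a labelled ligand from melanin-concentrating hormone receptor 1 (Homo sapiens) (a lower number here means a stronger inhibitor, a higher number a weaker inhibitor), compound 1 gives 4 nM and stands second highest of the three numbers: compound 2 gives 18.5 nM, a higher number beyond the scatter, and compound 3 gives 0.3 nM, a lower number beyond the scatter. Going by the values given here, the one step between measured compounds that differ in one place, a 62-fold lower number from compound 2 to compound 3 (1.79 log units; beyond the scatter), concerns the substituent on the shared core, not the aryl group of the acrylamide.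

Compound 4, `CCCc1cc(N)c2cc(NC(=O)/C=C/c3ccc(Br)cc3)ccc2n1`, has not yet been measured. It differs from compound 1 in one place: bromo in place of propyl on an aromatic carbon. The change sits on the phenyl of the acrylamide, para to a large group. Among the compounds with values here, no measured step bears on this position; the measured aryl groups carry propyl or trifluoromethyl, and the two trifluoromethyl compounds differ from each other on the core, so nothing separates the effect of the aryl substituent from that of the core substituent. Without a relevant step, the expected step of no change at the digits printed from compound 1 to compound 4 (within the scatter) is none beyond the scatter, with a wide range to cover the uncertainty. Compound 4 is therefore estimated at 4 nM, between 1.2 nM and 14 nM.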

Compound 4, half-maximal inhibitory concentration: 4 nM
For compound 4 middle estimate and measured number coincide at the digits printed; the measured number falls inside the stated range.
By their numbers in this assay, from the lowest: compound 3; then compounds 1 and 4 (each within the scatter of the next); then compound 2.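

The position on the phenyl of the acrylamide, para to a large group, now has its first direct reading: in this assay, replacing 4-propylphenyl with 4-bromophenyl gives no change at the digits printed from compound 1 to compound 4 (within the scatter) on the shared core with its propyl group. A propyl group of 3 heavy atoms and a single bromine therefore read alike here, so binding in this assay does not separate these two substituents. No measurement available for these compounds accounts for this result.

One pair cannot show how other groups at this position would read, such as an amine, a carboxylic acid or a longer chain such as hexyl. As far as these compounds go, it is also open whether bromo and propyl would still read alike with tert-butyl in place of the propyl on the core.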